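The source may report more compounds than this note shows. Statements on the series, on what has been measured and on what is new or still open speak of the compounds shown alone.

Compound 1 `Clc1ccc(OCc2cn(Cc3cccc(Cl)c3)nn2)cc1` and compound 2 `Clc1ccc(OCc2cn(Cc3ccc(Br)cc3)nn2)cc1` share one core and differ in a single place: 4-bromophenyl in place of 3-chlorophenyl on a saturated chain carbon bound to an aromatic nitrogen. In a physicochemical assay, read by spectrophotometry, with a stated time of 30 min (a higher number here means a weaker inhibitor, a lower number a stronger inhibitor), compound 1 gives 23.3 ug/mL, while compound 2 gives 11 ug/mL, a step of a 2.1-fold lower number from compound 1 to compound 2 (0.33 log units; beyond the scatter). Compound 3 `O=[N+]([O-])c1cccc(OCc2cn(Cc3cccc(Cl)c3)nn2)c1` is built on another core, and how that core differs from the core of compound 1 is not broken down here; in this assay compound 3 gives 31.2 ug/mL. Compound 4 `O=[N+]([O-])c1cccc(OCc2cn(Cc3ccc(Br)cc3)nn2)c1` has not yet been measured. Going by the values given here, it differs from compound 3 by 4-bromophenyl in place of 3-chlorophenyl on a saturated chain carbon bound to an aromatic nitrogen, the same change, at the same place, as the one from compound 1 to compound 2. Because that earlier step was a 2.1-fold lower number from compound 1 to compound 2 (0.33 log units; beyond the scatter), a step of similar size is expected, a 2.1-fold lower number from compound 3 to compound 4 (0.32 log units; beyond the scatter). Compound 4 is therefore estimated in this assay at 15 ug/mL, most likely between 8 ug/mL and 28 ug/mL.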

Compound 4, half-maximal inhibitory concentration: 29.4 ug/mL
Beside the measured number, compound 4's estimate is 2.0-fold (0.29 log units) below it; the whole stated range lies below it.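

In this assay the swap of 3-chlorophenyl for 4-bromophenyl gives a 1.1-fold lower number from compound 3 to compound 4 (0.03 log units; within the scatter), whereas on the core of compound 1 the same swap gave a 2.1-fold lower number from compound 1 to compound 2 (0.33 log units; beyond the scatter). The step therefore did not carry over in size from the core of compound 1 to the core of compound 3, although with a single pair on each core this says nothing about how the swap would behave on any further core. Nothing measured here explains the difference between the two cores.

The swap changes both the halogen and its place on the ring, and the compounds shown include neither 4-chlorophenyl nor 3-bromophenyl to separate the two. From the compounds shown here alone, how a carboxylic acid or an amine would fare on that ring also remains open.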